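The source may report more compounds than this note shows. Statements on the series, on what has been measured and on what is new or still open speak of the compounds shown alone.

Three urea compounds built on a shared core were tested in an ADME assay on the whole organism with Oryza sativa as the target, tested at 1 uM; a higher number here means a weaker effect of the compound at the concentration tested, a lower number a stronger effect. Compound 1 `C[C@@H](NC(=O)Nc1cccc(F)c1F)c1ccccc1` gives 99%, compound 2 `C[C@@H](NC(=O)Nc1cc(F)ccc1F)c1ccccc1` gives 100%, and compound 3 `C[C@@H](NC(=O)Nc1cccc(C(F)(F)F)c1F)c1ccccc1` gives 99%. Compound 3 differs from compound 1 by trifluoromethyl in place of fluoro on an aromatic carbon, and the step shows no change at the digits printed from compound 1 to compound 3 (within the scatter). Compound 2 has the same atoms as compound 1 joined differently; the difference between the two cores is not broken down here. Compound 4 `C[C@@H](NC(=O)Nc1cc(C(F)(F)F)ccc1F)c1ccccc1` awaits measurement and differs from compound 2 by trifluoromethyl in place of fluoro on an aromatic carbon. This is the same kind of change as from compound 1 to compound 3, though the surroundings differ: in compound 3 the new group is ortho to a fluoro group and meta to a large group, whereas in compound 4 it is meta to a large group and para to a fluoro group. Because the earlier step showed no change at the digits printed from compound 1 to compound 3 (within the scatter), the corresponding step is expected to be a number 1 percentage points lower from compound 2 to compound 4 (within the scatter). Compound 4 is therefore estimated at 99%.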

Compound 4, a percentage reported as activity, at one concentration (the size of the read-out at that concentration, not a potency): 70%
Compound 4: the middle estimate sits 29 percentage points above what was measured; measured number outside the range, below it.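

In this assay, the effect of putting trifluoromethyl in place of fluoro did not carry over unchanged from one core to the other: the same change on two cores in this assay, no change at the digits printed (within the scatter) from compound 1 to compound 3 and a number 30 percentage points lower (beyond the scatter) from compound 2 to compound 4, 30 percentage points apart, beyond the scatter of two such steps. On the core of compound 2, the step is a number 30 percentage points lower from compound 2 to compound 4 (beyond the scatter), which here means a stronger effect at the concentration tested. This shows that the outcome of the change depends on the core in this pair, but it does not show why, and two cores give no rule for any other core in the series.

The compounds shown leave open whether a chloro group, a methyl group or a nitrile on the same aromatic carbon would match compound 4. On these data alone, it also remains open whether the stronger effect of compound 4 holds at other concentrations.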